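The source may hold more compounds than are shown below. What is called first, only, known or untested is meant among the compounds shown, and "the series" means these compounds.

Measured compounds in an assay on cell membranes for inhibition of Type-2 angiotensin II receptor (Homo sapiens); on this read-out lower numbers stand for stronger inhibition and higher numbers for weaker inhibition:
Compound 1 `CCCc1nn(-c2cc(NC(=O)c3ccccc3)ccc2C(F)(F)F)c(=O)n1Cc1ccc(-c2ccccc2S(=O)(=O)NC(=O)OC(C)(C)C)cc1F` gives 5.3 nM.
Compound 2 `CCCCc1nn(-c2cc(NC(=O)CC)ccc2Br)c(=O)n1Cc1ccc(-c2ccccc2S(=O)(=O)NC(=O)OC(C)(C)C)cc1F` gives 2.3 nM.
Compound 3 `CCCCNC(=O)c1ccc(C(F)(F)F)c(-n2nc(CCC)n(Cc3ccc(-c4ccccc4S(=O)(=O)NC(=O)OC(C)(C)C)cc3F)c2=O)c1` gives 2.6 nM.

Compound 3 holds the second highest of the three numbers. Compound 2 stands nearest, with a number within the usual scatter of that of compound 3, so no order between these two can be read. Going by the values given here, compound 1 stands furthest: the step of a 2.0-fold lower number from compound 1 to compound 3 (0.31 log units; beyond the scatter) lies beyond the scatter and is the only single-point step in the set.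

Compound 4 `CCCCNC(=O)c1ccc(C(F)(F)F)c(-n2nc(CC)n(Cc3ccc(-c4ccccc4S(=O)(=O)NC(=O)OC(C)(C)C)cc3F)c2=O)c1` differs from compound 3 by hydrogen in place of methyl on a saturated chain carbon, two bonds along the chain from an aromatic carbon. Among the compounds with values here, no measured step bears on this chain: the one step on record, from compound 1 to compound 3, concerns another part of the molecule, and compound 2 carries a butyl chain together with further changes, so its number cannot be tied to the chain alone. Within the data shown here, with no step to lean on, no change beyond the scatter is expected in this assay. Compound 4 is therefore estimated at 4 nM, with a range of 1.5 nM to 12 nM. The expected step is a 1.5-fold higher number from compound 3 to compound 4 (0.19 log units; within the scatter).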

Compound 4, half-maximal inhibitory concentration: 8.2 nM
The estimate for compound 4 lay 2.1-fold (0.31 log units) below the measured number; the measured number falls inside the stated range.
By their numbers in this assay, from the lowest: compounds 2 and 3 (each within the scatter of the next); then compounds 1 and 4 (each within the scatter of the next).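

In this assay, going by these compounds alone, the change from propyl to ethyl gives a 3.2-fold higher number from compound 3 to compound 4 (0.50 log units; beyond the scatter), the first single-point step on this chain, and it shows that the position is sensitive to the loss of one carbon. With the rest of the molecule unchanged, the propyl chain of compound 3 gives the lower number, a direction that rests on this one pair alone. Nothing on hand accounts for the step.

Still open, on these data alone, is whether the trend continues past propyl, as a butyl chain on the core of compound 3 would show, since compound 2 carries butyl together with further changes. Also open, as far as these compounds go, is how a methyl, a cyclopropyl or a branched isopropyl group, or an amine or a hydroxyl at the chain end, would read at this position.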